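The source may hold more compounds than are shown below. What is called first, only, known or untested is meant among the compounds shown, and "the series" means these compounds.

Working notes on the series. In a functional assay on MCF7 cells (Homo sapiens) for inhibition, read by fluorescence, with a stated time of 72 h (a higher number here means a weaker inhibitor of growth, a lower number a stronger inhibitor of growth), compound 1 `COc1ccc(Cn2cnc3c(Nc4cccc(Cl)c4)nc(N[C@H]4CC[C@H](N)CC4)nc32)cc1` gives 4800 nM, compound 2 `CC(C)=CCn1cnc2c(Nc3cccc(Cl)c3)nc(N[C@H]3CC[C@H](N)CC3)nc21` gives 4200 nM and compound 3 `CCCCCCn1cnc2c(Nc3cc(OC)cc(OC)c3)nc(N[C@H]3CC[C@H](N)CC3)nc21` gives 3500 nM, so compound 3 stands within the scatter of both others. Compound 4 `CCCCCCn1cnc2c(Nc3cccc(Cl)c3)nc(N[C@H]3CC[C@H](N)CC3)nc21` remains unmeasured. Its difference from compound 3 is 3-chlorophenyl in place of 3,5-dimethoxyphenyl on a nitrogen on an aromatic ring. Among the measured compounds shown here, no measured step isolates this exchange. For the measured compounds named here, the one measured step, a 1.1-fold lower number from compound 1 to compound 2 (0.06 log units; within the scatter), lies elsewhere, on a saturated chain carbon bound to an aromatic nitrogen, and stays within the scatter. Compound 2 already carries 3-chlorophenyl at 4200 nM, so no shift beyond the scatter is expected in this assay. The expected change is a 1.1-fold higher number from compound 3 to compound 4 (0.06 log units; within the scatter). For compound 4 the estimated value is 4000 nM, with an expected range of 2000 nM to 8000 nM.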

Compound 4, concentration for 50% growth inhibition: 2700 nM
Estimate against measurement, compound 4: 1.5-fold (0.17 log units) above, and the stated range covers the measured number.
By their numbers in this assay, from the lowest: compounds 4, 3, 2 and 1 (each within the scatter of the next).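

In this assay the exchange of 3,5-dimethoxyphenyl for 3-chlorophenyl on a nitrogen on an aromatic ring is now isolated (a 1.3-fold lower number from compound 3 to compound 4 (0.11 log units; within the scatter)), and it does not separate the two groups. With 3-chlorophenyl held, the groups on the saturated chain carbon bound to an aromatic nitrogen are not separated either (a 1.6-fold lower number from compound 2 to compound 4 (0.19 log units; within the scatter); a 1.8-fold lower number from compound 1 to compound 4 (0.25 log units; within the scatter)). No supporting data bear on these steps. From the compounds shown here alone, whether a carboxylic acid on the phenyl ring, or a chain longer than pentyl, would give a step beyond the scatter stays open.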